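Nitro in Place of Chloro on the Shared Core

The source may report more compounds than this note shows. Statements on the series, on what has been measured and on what is new or still open speak of the compounds shown alone.

compound 1 `CCOC(=O)c1oc2ccc(NS(=O)(=O)c3ccc(Cl)cc3)cc2c1C`: 44000 nM
compound 2 `CCOC(=O)c1oc2ccc(NS(=O)(=O)c3ccccc3Cl)cc2c1C`: 137000 nM

In a functional assay on MDA-MB-468 cells (Homo sapiens) for antiproliferative activity, read by MTT assay, with a stated time of 72 h (a lower number here means a stronger inhibitor, a higher number a weaker inhibitor), compound 2 gives 137000 nM, the higher of the two numbers, and the step of a 3.1-fold higher number from compound 1 to compound 2 (0.49 log units; beyond the scatter) separates it from compound 1. Compound 3 `CCOC(=O)c1oc2ccc(NS(=O)(=O)c3ccccc3[N+](=O)[O-])cc2c1C` differs from compound 2 by nitro in place of chloro on an aromatic carbon. Among the compounds with values here, the one measured step concerns only where the chloro sits, not its exchange for nitro, so no measured step bears on this change. With nothing to guide it, the expected step is a 1.1-fold lower number from compound 2 to compound 3 (0.06 log units; within the scatter), not beyond the scatter. Compound 3 is therefore estimated at 120000 nM, within 40000 nM to 400000 nM.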

Compound 3, half-maximal inhibitory concentration: 96900 nM
For compound 3 the middle estimate is 1.2-fold (0.09 log units) above the measured one, within the range that was stated.
By their numbers in this assay, from the lowest: compound 1; then compounds 3 and 2 (each within the scatter of the next).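

At this position, on an aromatic carbon ortho to a large group, this assay does not separate nitro from chloro, since a 1.4-fold lower number from compound 2 to compound 3 (0.15 log units; within the scatter) stays within the scatter. The 2-nitrophenyl group of compound 3 nevertheless still gives a modest gap to the 4-chlorophenyl group of compound 1, with a 2.2-fold higher number from compound 1 to compound 3 (0.34 log units; beyond the scatter) lying beyond the scatter. Still open, as far as these compounds go, is whether an amine or a carboxylic acid here would read any differently, and how nitro would behave at the place of the chloro in compound 1. Nothing measured here explains these numbers.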